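This account rests on a few compounds, and the source may have more. Where it says the series, first, only, none or still open, it means among the compounds named here.

Compound 3 `COc1cc2c(cc1OC)C(CC(=O)Nc1ccc(C)cc1)CC2` gives 37% in a functional assay on the whole organism (strain Wistar) for inhibition, with Rattus norvegicus as the target, read by paw edema, with a stated time of 6 h, at a dose of 100 mg/kg (on this read-out lower numbers stand for less inhibition and higher numbers for more inhibition at the one dose given (going by the name of the read-out)), and stands with compound 1 `COc1cc2c(cc1OC)C(CC(=O)Nc1ccccc1)CC2` at 38.9% and compound 2 `COc1cc2c(cc1OC)C(CC(=O)Nc1cccc(Cl)c1)CC2` at 38.9%, all three within the scatter of one another. Compound 4 `COc1ccccc1NC(=O)CC1CCc2cc(OC)c(OC)cc21` differs from compound 3 by 2-methoxyphenyl in place of 4-methylphenyl on an amide-type nitrogen. For the measured compounds named here, the steps that bear on this are the earlier changes on the group attached to the amide-type nitrogen: no change at the digits printed from compound 1 to compound 2 (within the scatter) and a number 1.9 percentage points lower from compound 1 to compound 3 (within the scatter), together with the one exchange of a whole substituted phenyl for another, a number 1.9 percentage points lower from compound 2 to compound 3 (within the scatter). None reaches beyond the scatter, so for compound 4 no step beyond the scatter is expected in this assay, a number 1 percentage points higher from compound 3 to compound 4 (within the scatter). The estimate for compound 4 is 38%, with a range from 28% to 48%.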

Compound 4, a percentage reported as inhibition, in the whole organism at one dose (the size of the read-out at that dose, not a potency): 24.1%
For compound 4 the middle estimate is 13.9 percentage points above the measured one; measured number below the stated range.
By their numbers in this assay, from the lowest: compound 4; then compounds 3, 1 and 2 (each within the scatter of the next).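

For the compounds shown here, on the group attached to the amide-type nitrogen, 2-methoxyphenyl is the only change in this assay that goes beyond the scatter: a number 14.8 percentage points lower from compound 1 to compound 4 (beyond the scatter) for methoxy in place of hydrogen, a number 14.8 percentage points lower from compound 2 to compound 4 (beyond the scatter) against 3-chlorophenyl, and a number 12.9 percentage points lower from compound 3 to compound 4 (beyond the scatter) against 4-methylphenyl. The read-out at this position therefore does respond to the aromatic substituent, although chloro and methyl in place of hydrogen stayed within the scatter. Nothing at hand explains the lower number.

From the compounds shown here alone, whether the lower number follows the methoxy group itself or its placing on the ring stays open. Values for 4-methoxyphenyl and 2-methylphenyl on the same nitrogen would separate the two.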